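The source may hold more compounds than are shown below. What is called first, only, known or untested is meant among the compounds shown, and "the series" means these compounds.

Three compounds share one core, which differs between them only in two places. Compound 1 `N#Cc1ccc(S(=O)(=O)N2C/C(=C\c3cccnc3)C(=O)/C(=C/c3ccccc3F)C2)cc1`, compound 2 `CC(=O)Nc1ccc(S(=O)(=O)N2C/C(=C\c3cccnc3)C(=O)/C(=C/c3ccccc3F)C2)cc1` and compound 3 `N#Cc1ccc(S(=O)(=O)N2C/C(=C\c3ccncc3)C(=O)/C(=C/c3ccccc3F)C2)cc1` were each tested in a functional assay on QGY-7703 cells (Homo sapiens) for cytotoxicity, read by MTT assay, with a stated time of 24 h; on this read-out higher numbers stand for weaker inhibition and lower numbers for stronger inhibition. Compound 1 gives 15800 nM, compound 2 gives 9640 nM and compound 3 gives 8500 nM in this assay. The change acetamido in place of cyano on an aromatic carbon made the step of a 1.6-fold lower number from compound 1 to compound 2 (0.21 log units; within the scatter). The cores of compound 1 and compound 3 differ by pyridin-4-yl in place of pyridin-3-yl on a double-bonded chain carbon bound to a double-bonded ring carbon, a step of a 1.9-fold lower number from compound 1 to compound 3 (0.27 log units; within the scatter).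

Compound 4 `CC(=O)Nc1ccc(S(=O)(=O)N2C/C(=C\c3ccncc3)C(=O)/C(=C/c3ccccc3F)C2)cc1` has not yet been measured. It differs from compound 3 by acetamido in place of cyano on an aromatic carbon, the same change as from compound 1 to compound 2; among these compounds it occurs twice. Because that earlier step was a 1.6-fold lower number from compound 1 to compound 2 (0.21 log units; within the scatter), a step of similar size is expected from compound 3 to compound 4, namely a 1.4-fold lower number from compound 3 to compound 4 (0.15 log units; within the scatter). For compound 4 the expected value in this assay is 6000 nM, likely between 3000 nM and 12000 nM.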

Compound 4, half-maximal inhibitory concentration: 13700 nM
Estimate against measurement, compound 4: 2.3-fold (0.36 log units) below; the whole stated range lies below it.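

In this assay, acetamido in place of cyano gave a 1.6-fold higher number from compound 3 to compound 4 (0.21 log units; within the scatter), and pyridin-4-yl in place of pyridin-3-yl gave a 1.4-fold higher number from compound 2 to compound 4 (0.15 log units; within the scatter). Carried to a second core, the cyano to acetamido change gives a step that cannot be told apart from the first: the same change on two cores in this assay, a 1.6-fold lower number (0.21 log units; within the scatter) from compound 1 to compound 2 and a 1.6-fold higher number (0.21 log units; within the scatter) from compound 3 to compound 4, 2.6-fold (0.42 log units) apart, within the scatter of two such steps The pyridine change reads the same way, so nothing here shows that the two cores respond differently, but with every step inside the scatter, nothing shows that either change has a real effect or that such an effect carries over: the same change on two cores in this assay, a 1.9-fold lower number (0.27 log units; within the scatter) from compound 1 to compound 3 and a 1.4-fold higher number (0.15 log units; within the scatter) from compound 2 to compound 4, 2.6-fold (0.42 log units) apart, within the scatter of two such steps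

Going by these compounds, it remains open whether a different group on the same aromatic carbon, such as an amine or a carboxylic acid, would give a step beyond the scatter. On these data alone, it also remains open whether such a step would hold on both cores.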